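Benzyl-series permeability notes: estimate for compound 4

This account rests on a few compounds, and the source may have more. Where it says the series, first, only, none or still open, it means among the compounds named here.

Measured so far in an ADME assay for permeability, using PAMPA, with a stated time of 30 min, at pH 7.4; on this read-out higher numbers stand for higher permeability and lower numbers for lower permeability:
compound 1 `c1ccc(-c2ccc3c(NCCCNCc4ccco4)ccnc3c2)cc1` gives 237 10^-6 cm/s
compound 2 `Fc1ccc(Cc2ccc3c(NCCCNCc4ccco4)ccnc3c2)c(Cl)c1` gives 23 10^-6 cm/s
compound 3 `COc1cccc(CNCCCNc2ccnc3cc(Cc4ccc(F)cc4Cl)ccc23)c1O` gives 23 10^-6 cm/s

Compound 2 sits at the bottom of these three numbers together with compound 3, the two being level at the digits shown: no change at the digits printed from compound 2 to compound 3 (within the scatter). Among the compounds with values here, the only large step in the set runs the other way, from compound 1 to compound 2: a 10-fold lower number from compound 1 to compound 2 (1.01 log units; beyond the scatter), where the shared core carries the phenyl directly on the aromatic carbon in compound 1 and the substituted benzyl in compound 2.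

Compound 4 `FC(F)(F)c1cccc(Cc2ccc3c(NCCCNCc4ccco4)ccnc3c2)c1` keeps the benzyl arrangement of compound 2 and changes only the aryl on it: 3-(trifluoromethyl)phenyl in place of 2-chloro-4-fluorophenyl on a saturated chain carbon bound to an aromatic carbon.

Within the data shown here, no measured step exchanges one substituted benzyl for another, so neither step speaks directly to this change. The step from compound 1 to compound 2 shows that this part of the molecule can move this assay strongly, but it also changes the attachment, which compound 4 keeps. The step from compound 2 to compound 3, at the far end of the chain, shows no movement. The expectation is therefore a step within the usual scatter in either direction, a 1.1-fold higher number from compound 2 to compound 4 (0.05 log units; within the scatter), leaving compound 4 near compound 2. Compound 4 is estimated at 26 10^-6 cm/s, with a range of 10 10^-6 cm/s to 65 10^-6 cm/s.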

Compound 4, apparent permeability: 23 10^-6 cm/s
Beside the measured number, compound 4's estimate is 1.1-fold (0.05 log units) above it, and the stated range covers the measured number.
By their numbers in this assay, from the lowest: compounds 2, 3 and 4 (each within the scatter of the next); then compound 1.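

Within the data shown here, exchanging the aryl while keeping the benzyl attachment gives no change at the digits printed from compound 2 to compound 4 (within the scatter) in this assay, the direct reading for this position that the earlier steps could not supply. Among these compounds, on a saturated chain carbon bound to an aromatic carbon, 2-chloro-4-fluorophenyl and 3-(trifluoromethyl)phenyl are therefore not told apart by this read-out, even though they share no substituent, and the large step seen with a 10-fold lower number from compound 1 to compound 2 (1.01 log units; beyond the scatter) finds no counterpart in this exchange. No available evidence accounts for this result.

On these data alone, whether the read-out stays level with an aryl carrying an amine or a carboxylic acid, or with a longer chain in place of the benzyl carbon, remains open. Also open, as far as these compounds go, is how much of the step from phenyl to substituted benzyl belongs to the attachment and how much to the substituents, which an unsubstituted benzyl would separate.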